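Compound 2 to compound 4: a side-chain change

The compounds below may be only part of what the source reports. "The series", "measured", "known", "first", "only" and "open" are said of these compounds alone.

Measured in a physicochemical assay for solubility; on this read-out lower numbers stand for lower solubility and higher numbers for higher solubility (each value a limit)
- compound 1 `CCOc1ccc2c(c1)C=CN(C)C(=O)C2C` gives >= 120 ug/mL as a limit
- compound 2 `COCCOc1ccc2c(c1)C=CN(C)C(=O)[C@@H]2C` gives >= 128 ug/mL as a limit
- compound 3 `CC1C(=O)N(C)C=Cc2cc(OCC(C)(C)O)ccc21` gives >= 131 ug/mL as a limit

As far as these compounds go, compound 2 stands at >= 128 ug/mL as a limit, so its exact position is unknown. Compound 4 `C[C@H]1C(=O)N(C)C=Cc2cc(OC(CO)CO)ccc21` differs from compound 2 by 2-hydroxy-1-(hydroxymethyl)ethyl in place of 2-methoxyethyl on an oxygen on an aromatic ring on the shared core. Of the measured steps, only a step that the two limits leave unreadable from compound 1 to compound 3 bears on this change, and it offers no readable size. Compound 3 gives >= 131 ug/mL as a limit. No step beyond the scatter is therefore expected in this assay in either direction. The expected step is a step that the limit leaves unreadable from compound 2 to compound 4 in size. The estimate for compound 4 is 133 ug/mL with an expected range from 100 ug/mL to 170 ug/mL in this read-out.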

Compound 4, solubility: >= 142 ug/mL
Compound 4 ended at the assay's limit; the forecaster's own chance of this, stated with the estimate: 85%; middle value at least 1.0-fold (0.02 log units) away from the limit.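

In this assay compound 4 gives >= 142 ug/mL, which is a limit. Going by these compounds alone, compound 2 also stands only at a limit, so no step between compound 2 and compound 4 can be read. As far as these compounds go, whether 2-hydroxy-1-(hydroxymethyl)ethyl in place of 2-methoxyethyl shifts this assay at all stays open.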